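The compounds below may be only part of what the source reports. "The series", "measured", "known", "first", "only" and "open" are said of these compounds alone.

In an assay on isolated protein for inhibition of histone deacetylase 8 (Homo sapiens) (on this read-out lower numbers stand for stronger inhibition and higher numbers for weaker inhibition), three compounds have been measured:

compound 1 `Cc1ccc(C(=O)c2ccc3c(ccn3Cc3ccc(C(=O)NO)cc3)c2)cc1`: 1490 nM
compound 2 `COc1ccc(C(=O)c2ccc3c(ccn3Cc3ccc(C(=O)NO)cc3)c2)cc1OC`: 756 nM
compound 3 `COc1ccc(C(=O)c2ccc3c(ccn3Cc3ccc(/C=C/C(=O)NO)cc3)c2)cc1`: 2810 nM

Compound 3 gives the highest of the three numbers. Its nearest neighbour is compound 1, whose value is within the scatter of that of compound 3, while compound 2 lies furthest away, with a gap that is beyond the scatter. Going by the values given here, the only measured step, a 2.0-fold lower number from compound 1 to compound 2 (0.29 log units; within the scatter), concerns a change on the carbonyl carbon and is within the scatter.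

Compound 4 `COc1ccc(C(=O)c2ccc3c(ccn3Cc3ccc(C(=O)NO)cc3)c2)cc1` has not yet been measured. It differs from compound 3 in a single place: hydroxycarbamoyl in place of 2-(hydroxycarbamoyl)ethenyl on an aromatic carbon. Among the compounds with values here, no measured pair differs in just this way, so no step bears directly on the change. Compound 4 carries the same hydroxycarbamoyl group as compounds 1 and 2, and its aryl group on the carbonyl carbon sits between those two compounds in substitution, so compound 4 is expected to land near their values, with a 2.8-fold lower number from compound 3 to compound 4 (0.45 log units; beyond the scatter) as the estimated step. Compound 4 is therefore estimated at 1000 nM, within a range from 400 nM to 2500 nM.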

Compound 4, half-maximal inhibitory concentration: 646 nM
The estimate for compound 4 lay 1.5-fold (0.19 log units) above the measured number; low and high end bracket the measured number.
By their numbers in this assay, from the lowest: compounds 4, 2, 1 and 3 (each within the scatter of the next, the first and the last beyond it).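

In this assay the position on the aromatic carbon proves sensitive to the group it carries: hydroxycarbamoyl in place of 2-(hydroxycarbamoyl)ethenyl gives a 4.3-fold lower number from compound 3 to compound 4 (0.64 log units; beyond the scatter), though this rests on a single pair. On the aryl group at the carbonyl, methoxy in place of methyl gives a 2.3-fold lower number from compound 1 to compound 4 (0.36 log units; beyond the scatter), whereas hydrogen in place of methoxy gives a 1.2-fold lower number from compound 2 to compound 4 (0.07 log units; within the scatter), so the second methoxy of compound 2 makes no readable difference. Nothing available accounts for either result.

From the compounds shown here alone, whether the step from 2-(hydroxycarbamoyl)ethenyl to hydroxycarbamoyl would be the same with another aryl group on the carbonyl remains open. So does what a longer saturated chain before the hydroxycarbamoyl, or a carboxylic acid in its place, would do at this position.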